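The compounds below may be only part of what the source reports. "The series", "measured", "known", "first", "only" and "open" are said of these compounds alone.

Measured so far:
compound 1, `O=Cc1ccc(-c2cn3ccnc3c(-c3ccc4ncn(C5CCCCC5)c4c3)n2)cc1`: in a functional assay on LOX IMVI cells (Homo sapiens) for inhibition, read by sulforhodamine B assay, with a stated time of 48 h, tested at 10 uM (on this read-out higher numbers stand for more inhibition at the one concentration tested (going by the name of the read-out) and lower numbers for less inhibition), compound 1 gives 46.9%.
compound 2, `Clc1ccc(-c2cn3ccnc3c(-c3ccc4ncn(C5CCCCC5)c4c3)n2)cc1`: in this assay compound 2 gives 14.8%.

Compound 1 stands highest of the two numbers in hand. Among the compounds with values here, the only measured step away from it is a number 32.1 percentage points lower from compound 1 to compound 2 (beyond the scatter), which puts compound 2 well below compound 1 and beyond the scatter. That step alters the group on the aromatic carbon at the far end of the shared core and leaves the aromatic nitrogen untouched.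

Compound 3, `O=Cc1ccc(-c2cn3ccnc3c(-c3ccc4ncn(Cc5ccccc5)c4c3)n2)cc1`, differs from compound 1 at that other position, (benzyl in place of cyclohexyl on an aromatic nitrogen). Within the data shown here, no measured step bears on this place, so neither direction nor size can be read from the data; the step from compound 1 to compound 2 is the only comparison available and it concerns a different site. With nothing to anchor a change, the step of a number 4.9 percentage points lower from compound 1 to compound 3 (within the scatter) is expected to fall within the scatter, but with a wide allowance either way. For compound 3 in this assay the estimate is 42%, ranging from 15% to 68%.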

Compound 3, a percentage reported as inhibition, at one concentration (the size of the read-out at that concentration, not a potency): 46.9%
Estimate against measurement, compound 3: 4.9 percentage points below, within the range that was stated.
By their numbers in this assay, from the lowest: compound 2; then compounds 1 and 3 (each within the scatter of the next).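

In this assay, the aromatic nitrogen gets its first direct reading: benzyl in place of cyclohexyl gives no change at the digits printed from compound 1 to compound 3 (within the scatter) with the formyl group held in place. Across these three compounds, the exchange of a six-membered non-aromatic ring for benzyl at this nitrogen leaves the read-out within the scatter, whereas the single change on the aromatic carbon at the other site gives a number 32.1 percentage points lower from compound 1 to compound 2 (beyond the scatter) and stands beyond it. No measurement in hand bears on why cyclohexyl and benzyl read alike here.

Going by these compounds, whether the two groups also read alike with chloro in place of formyl remains open, as does whether they would match at any concentration other than the one tested. Also open is how far this match extends to other groups on the aromatic nitrogen, such as a longer alkyl chain, a chain ending in an amine, or a benzyl carrying a carboxylic acid; both groups shown hold carbon only.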